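A Side-Chain Change from the Lowest Number So Far

The source may hold more compounds than are shown below. What is called first, only, known or untested is meant among the compounds shown, and "the series" means these compounds.

Of the compounds shown here, three sharing one core have been measured in a functional assay on the whole organism with Rattus norvegicus as the target; a higher number here means that more compound is needed for the effect, a lower number that less compound is needed. Compound 1 `N#CCn1c(=N)sc2cc(OC(F)(F)F)ccc21` gives 3.5 mg/kg, compound 2 `N=c1sc2cc(OC(F)(F)F)ccc2n1CC(N)=O` gives 7 mg/kg, and compound 3 `C[S+]([O-])CCn1c(=N)sc2cc(OC(F)(F)F)ccc21` gives 1.1 mg/kg, the lowest number of the three. The two steps that reach compound 3 both lie beyond the scatter: a 3.2-fold lower number from compound 1 to compound 3 (0.50 log units; beyond the scatter) and a 6.4-fold lower number from compound 2 to compound 3 (0.80 log units; beyond the scatter). The remaining step, a 2.0-fold higher number from compound 1 to compound 2 (0.30 log units; within the scatter), stays within the scatter.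

Compound 4 `CSCCCn1c(=N)sc2cc(OC(F)(F)F)ccc21` has not yet been measured. Its difference from compound 3 is a group of 3 heavy atoms (2 carbon, 1 sulfur; no ring) in place of a group of 3 heavy atoms (1 carbon, 1 oxygen, 1 sulfur; no ring), on a saturated chain carbon, two bonds along the chain from an aromatic nitrogen. All three measured steps exchange the group on a saturated chain carbon bound to an aromatic nitrogen, so they show how far this part of the structure can move the number. None of them, however, introduces (methylsulfanyl)methyl, so they offer only an indirect guide. The largest of them, a 6.4-fold lower number from compound 2 to compound 3 (0.80 log units; beyond the scatter), is modest, which argues against expecting a large change. For the measured compounds named here, since compound 3 holds the lowest value so far, a modest rise seems likelier than a further fall, and the expected step, a 1.8-fold higher number from compound 3 to compound 4 (0.26 log units; within the scatter), is small. Compound 4 is estimated at 2 mg/kg, with an expected range from 0.8 mg/kg to 5 mg/kg.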

Compound 4, dose for half-maximal effect: 4.2 mg/kg
The estimate for compound 4 lay 2.1-fold (0.32 log units) below the measured number; measured number inside the range.
By their numbers in this assay, from the lowest: compound 3; then compounds 1, 4 and 2 (each within the scatter of the next).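

In this assay, the change at this position, on a saturated chain carbon, two bonds along the chain from an aromatic nitrogen, gives a 3.8-fold higher number from compound 3 to compound 4 (0.58 log units; beyond the scatter) even though the leaving and entering groups differ only by the oxygen on sulfur, so this single atom carries a change beyond the scatter. For the compounds shown here, the other two steps put (methylsulfanyl)methyl on the same footing as the shorter side chains, with a 1.7-fold lower number from compound 2 to compound 4 (0.22 log units; within the scatter) and a 1.2-fold higher number from compound 1 to compound 4 (0.08 log units; within the scatter) both printed as within the scatter, which leaves compound 3 as the only one of the four compounds set apart from all the others. Nothing available here accounts for what the oxygen on sulfur does in this whole-animal read-out.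

The compounds shown leave open whether the low number of compound 3 is particular to the oxygen on sulfur or would also appear with a sulfone or a methyl ether at the end of the same chain. They also leave open how the number responds to a longer chain between the aromatic nitrogen and the sulfur, or to an amine at that chain end.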